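The source may hold more compounds than are shown below. What is called first, only, known or untested is meant among the compounds shown, and "the series" means these compounds.

Measured so far in a functional assay on A-375 cells (Homo sapiens) for cytotoxicity, read by MTT assay; a higher number here means a weaker inhibitor, a lower number a stronger inhibitor:
Compound 1 `O=C(NCCCNc1nccc(-c2c(-c3cccc(F)c3)nc3sccn23)n1)c1ccc(F)cc1` — 14900 nM
Compound 2 `O=C(NCCNc1nccc(-c2c(-c3cccc(F)c3)nc3sccn23)n1)c1ccc(Cl)cc1` — 2570 nM
Compound 3 `O=S(=O)(NCCCNc1nccc(-c2c(-c3cccc(F)c3)nc3sccn23)n1)c1ccc(Cl)cc1` — 5900 nM

Compound 3 stands second highest of these three numbers. Compound 4 `Cc1ccc(S(=O)(=O)NCCNc2nccc(-c3c(-c4cccc(F)c4)nc4sccn34)n2)cc1` has not yet been measured. Its change from compound 3 is ((4-methylphenyl)sulfonyl)amino in place of (((4-chlorophenyl)sulfonyl)amino)methyl on a saturated chain carbon, two bonds along the chain from a nitrogen on an aromatic ring. For the measured compounds named here, two measured steps bear on it: a 5.8-fold lower number from compound 1 to compound 2 (0.76 log units; beyond the scatter) and a 2.3-fold higher number from compound 2 to compound 3 (0.36 log units; beyond the scatter). Both steps that shorten the chain between the aromatic nitrogen and the amide or sulfonamide nitrogen go with a lower number, so the shortening in compound 4 is expected to lower it too, modestly, with a 2.4-fold lower number from compound 3 to compound 4 (0.37 log units; beyond the scatter). The estimate for compound 4 is 2500 nM, in the range 900 nM to 7000 nM.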

Compound 4, half-maximal inhibitory concentration: 15400 nM
Compound 4: middle estimate off by 6.2-fold (0.79 log units), on the low side; measured number above the stated range.
By their numbers in this assay, from the lowest: compound 2; then compound 3; then compounds 1 and 4 (each within the scatter of the next).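

Shortening the chain does not lower the number on its own: a 2.6-fold higher number from compound 3 to compound 4 (0.42 log units; beyond the scatter), the opposite of what compound 2 suggested. With the shorter chain kept, placing (4-methylphenyl)sulfonyl where (4-chlorophenyl)carbonyl stood on the amine nitrogen gives a 6.0-fold higher number from compound 2 to compound 4 (0.78 log units; beyond the scatter), so this group matters at least as much as chain length, while a 1.0-fold higher number from compound 1 to compound 4 (0.01 log units; within the scatter) leaves those two compounds indistinguishable. Nothing available explains these shifts.

Chain length and the chlorine-to-methyl swap change together in compound 4, so their separate contributions remain unresolved. Also open, on these data alone, is how a 4-methoxyphenyl group or a still longer chain would behave.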